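The source may hold more compounds than are shown below. What is called first, only, known or untested is meant among the compounds shown, and "the series" means these compounds.

Of the compounds shown here, three from this series have been tested in an ADME assay on HEK293 cells (Homo sapiens) for cytotoxicity, read by MTT assay, with a stated time of 48 h (on this read-out lower numbers stand for stronger inhibition and higher numbers for weaker inhibition), so far. Compound 1, `CCN(CC)CCn1c(N)c(-c2nc3ccccc3[nH]2)c2nc(C#N)c(C#N)nc21`, gives 12200 nM in this assay. Compound 2, `CN(C)CCCn1c(N)c(-c2nc3ccccc3[nH]2)c2nc(C#N)c(C#N)nc21`, carries the change (dimethylamino)methyl in place of diethylamino on a saturated chain carbon, two bonds along the chain from an aromatic nitrogen relative to compound 1, and compound 2 gives 8360 nM in this assay; the step of a 1.5-fold lower number from compound 1 to compound 2 (0.16 log units; within the scatter) shows that this change made little difference. Compound 3, `CCN(CC)CCn1c(N)c(-c2nc3ccccc3n2C)c2nc(C#N)c(C#N)nc21`, differs from compound 1 in its core by methyl in place of hydrogen on an aromatic nitrogen, and compound 3 gives 25400 nM in this assay, the step being a 2.1-fold higher number from compound 1 to compound 3 (0.32 log units; beyond the scatter). Compound 3 has the highest number of the three measured compounds.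

Compound 4, `CN(C)CCCn1c(N)c(-c2nc3ccccc3n2C)c2nc(C#N)c(C#N)nc21`, is not yet measured. It stands to compound 3 as compound 2 stands to compound 1: the change is (dimethylamino)methyl in place of diethylamino on a saturated chain carbon, two bonds along the chain from an aromatic nitrogen, made on the core of compound 3 rather than the core of compound 1, and the place of the change is the same in both pairs. Since the same change from compound 1 to compound 2 produced only the small step of a 1.5-fold lower number from compound 1 to compound 2 (0.16 log units; within the scatter), the expectation is that compound 4 will move from compound 3 by a step of similar size, estimated as a 1.5-fold lower number from compound 3 to compound 4 (0.16 log units; within the scatter). On that basis compound 4 is estimated to give 17500 nM in this assay. The expected range for compound 4 runs from 9000 nM to 34000 nM, which is wide because a 1.5-fold lower number from compound 1 to compound 2 (0.16 log units; within the scatter) itself lay within the scatter and the pattern rests on that single measured pair.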

Compound 4, half-maximal inhibitory concentration: 8410 nM
Beside the measured number, compound 4's estimate is 2.1-fold (0.32 log units) above it; measured number below the stated range.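

In this assay, the chain change on the core of compound 3 gives a 3.0-fold lower number from compound 3 to compound 4 (0.48 log units; beyond the scatter), and methyl in place of hydrogen on an aromatic nitrogen, with the 3-(dimethylamino)propyl chain in place, gives a 1.0-fold higher number from compound 2 to compound 4 (0.00 log units; within the scatter). Set beside its earlier step, the chain change carries from one core to the other with no gap beyond the scatter, although only the later step itself lies beyond it: the same change on two cores in this assay, a 1.5-fold lower number (0.16 log units; within the scatter) from compound 1 to compound 2 and a 3.0-fold lower number (0.48 log units; beyond the scatter) from compound 3 to compound 4, 2.1-fold (0.32 log units) apart, within the scatter of two such steps The methyl change likewise carries over between the two chains, but each comparison rests on a single pair of steps, so this shows only that the two changes stay within the scatter across these four compounds, not that the steps are equal or that they would hold on any other core: the same change on two cores in this assay, a 2.1-fold higher number (0.32 log units; beyond the scatter) from compound 1 to compound 3 and a 1.0-fold higher number (0.00 log units; within the scatter) from compound 2 to compound 4, 2.1-fold (0.32 log units) apart, within the scatter of two such steps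

The compounds shown leave open whether the same agreement would hold for other groups on the chain, such as a morpholine, a piperidine or a longer chain, or for ethyl or benzyl in place of the methyl on the aromatic nitrogen. They also leave open what would happen if an amide or a carboxylic acid stood in place of a nitrile on the shared core.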